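The compounds below may be only part of what the source reports. "The series", "measured", "known", "first", "only" and "open" are said of these compounds alone.

Compound 1 `CCn1c(C(=O)NCCC(=O)OC)ccc1C(CC)(CC)c1ccc(OCS(=O)(=O)c2ccccc2)c(C)c1` gives 40400 nM in a functional assay on PC-3 cells (Homo sapiens) for antiproliferative activity, read by MTT assay, with a stated time of 24 h (a lower number here means a stronger inhibitor, a higher number a weaker inhibitor), the highest number among the three measured compounds. Compound 2 `CCn1c(C(=O)N[C@H](CO)C(C)C)ccc1C(CC)(CC)c1ccc(OCS(=O)(=O)c2ccccc2)c(C)c1` gives 7300 nM and compound 3 `CCn1c(C(=O)N[C@H](CO)CCO)ccc1C(CC)(CC)c1ccc(OCS(=O)(=O)c2ccccc2)c(C)c1` gives 12100 nM. Both differ from compound 1 at the same amide-type nitrogen as the change now considered: a 5.5-fold lower number from compound 1 to compound 2 (0.74 log units; beyond the scatter) and a 3.3-fold lower number from compound 1 to compound 3 (0.52 log units; beyond the scatter). Compound 4 `CCn1c(C(=O)NC2(C(=O)O)CC2)ccc1C(CC)(CC)c1ccc(OCS(=O)(=O)c2ccccc2)c(C)c1` departs from compound 1 at that nitrogen as well; the change is 1-carboxycyclopropyl in place of 2-(methoxycarbonyl)ethyl on an amide-type nitrogen. Neither measured step involves a carboxy group or a three-membered ring, so they guide only loosely; both replacements of the 2-(methoxycarbonyl)ethyl group measured so far gave modest lower numbers. The expectation for compound 4 is therefore a modest step, a 2.7-fold lower number from compound 1 to compound 4 (0.43 log units; beyond the scatter). Compound 4 is estimated at 15000 nM, within 5000 nM to 45000 nM.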

Compound 4, half-maximal inhibitory concentration: 26300 nM
Compound 4: middle estimate off by 1.8-fold (0.24 log units), on the low side; the measured number falls inside the stated range.
By their numbers in this assay, from the lowest: compounds 2 and 3 (each within the scatter of the next); then compounds 4 and 1 (each within the scatter of the next).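

In this assay, within the data shown here, 1-carboxycyclopropyl is the first replacement of 2-(methoxycarbonyl)ethyl on the amide-type nitrogen whose step stays within the scatter (a 1.5-fold lower number from compound 1 to compound 4 (0.19 log units; within the scatter)). Not every replacement at this nitrogen therefore gives a step beyond the scatter from compound 1; compound 4 goes against the pattern set by compounds 2 and 3. The position also separates the replacements from one another (a 2.2-fold higher number from compound 3 to compound 4 (0.34 log units; beyond the scatter); a 3.6-fold higher number from compound 2 to compound 4 (0.56 log units; beyond the scatter)).

From the compounds shown here alone, whether the three-membered ring or the carboxy group sets this result stays open, as does the reading for an open-chain carboxylic acid or an amine on this nitrogen. No measurement at hand accounts for these differences.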